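Swapping nitro for fluoro on a benzamide

The source may hold more compounds than are shown below. What is called first, only, known or untested is meant among the compounds shown, and "the series" means these compounds.

The starting point is compound 2, `COc1cc(NC(=O)c2ccc([N+](=O)[O-])cc2)cc(OC)c1OC`. In a functional assay on ONS-76 cells (Homo sapiens) for cytotoxicity, read by MTT assay, with a stated time of 72 h (a lower number here means a stronger inhibitor, a higher number a weaker inhibitor), compound 2 gives only a limit, >= 125000 nM. Compound 1, `COc1cc(N(C)C(=O)c2ccc(F)cc2)cc(OC)c1OC`, likewise gives only a limit in this assay, at >= 125000 nM. Both measured values thus sit at the same edge of what the test can report, (the limit of >= 125000 nM in this assay, at which 2 of the 2 values shown sit). The unmeasured compound 3, `COc1cc(NC(=O)c2ccc(F)cc2)cc(OC)c1OC`, differs from compound 2 by fluoro in place of nitro on an aromatic carbon. Among the compounds with values here, no step between measured compounds is available, so no size of effect can be read from the data. The expectation is no move beyond the scatter, a number no higher from compound 2 to compound 3 (the limit leaves the size open). Compound 3 is expected to give about 125000 nM, within 40000 nM to 400000 nM, most likely again only as a limit.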

Compound 3, half-maximal inhibitory concentration: >= 125000 nM
Compound 3 ended at the assay's limit (the forecaster's own chance of this, stated with the estimate: 80%); the middle value sits exactly at the limit.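

Within the data shown here, compound 1, compound 2 and compound 3 all stop at one limit of the test, so no step between them can be read: the limit of >= 125000 nM in this assay, at which 3 of the 3 values shown sit. On these data alone, how strongly each compound inhibits in this assay, and so how fluoro compares with nitro, stays open.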